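The source may report more compounds than this note shows. Statements on the series, on what has been measured and on what is new or still open speak of the compounds shown alone.

Measured so far in a functional assay on DU-145 cells (Homo sapiens) for inhibition, read by trypan blue exclusion, with a stated time of 96 h; on this read-out lower numbers stand for stronger inhibition of growth and higher numbers for weaker inhibition of growth:
compound 1, `CN(C)c1ccc(/C=C(/SCc2ccc(F)cc2)C(=O)c2ccc(Br)cc2)cc1` — 50000 nM
compound 2, `O=C(/C(=C\c1ccc(O)cc1)SCc1ccc(Cl)cc1)c1ccc(Br)cc1` — 10000 nM
compound 3, `O=C(/C(=C\c1ccc2ccccc2n1)SCc1ccc(F)cc1)c1ccc(Br)cc1` — 25000 nM

Compound 3 stands second highest of the three numbers. Its nearest neighbour is compound 1, which lies within the scatter of it, as the step of a 2.0-fold lower number from compound 1 to compound 3 (0.30 log units; within the scatter) shows; compound 2 is furthest, and that gap lies beyond the scatter.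

The next compound is compound 4, `O=C(/C(=C\c1ccc(O)cc1)SCc1ccc(F)cc1)c1ccc(Br)cc1`. Relative to compound 3 the change is 4-hydroxyphenyl in place of quinolin-2-yl on a double-bonded chain carbon bound to a double-bonded chain carbon.

Within the data shown here, only one measured step bears on this position: a 2.0-fold lower number from compound 1 to compound 3 (0.30 log units; within the scatter), which was within the scatter. Among the measured compounds shown here, no measured step introduces 4-hydroxyphenyl itself. What is known is that compound 2 carries 4-hydroxyphenyl at the same place and gives 10000 nM in this assay, the lowest number of the three. On that basis the expected move from compound 3 is a modest lowering, of roughly the size seen between compound 3 and compound 2, without strong confidence.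

The estimate for compound 4 is therefore 12000 nM, with a range of 5000 nM to 30000 nM, the expected step being a 2.1-fold lower number from compound 3 to compound 4 (0.32 log units; beyond the scatter).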

Compound 4, concentration for 50% growth inhibition: 10000 nM
Compound 4: the middle estimate sits 1.2-fold (0.08 log units) above what was measured, and the stated range covers the measured number.
By their numbers in this assay, from the lowest: compounds 2 and 4 (each within the scatter of the next); then compounds 3 and 1 (each within the scatter of the next).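

In this assay, the position on a double-bonded chain carbon bound to a double-bonded chain carbon now shows a change beyond the scatter, with 4-hydroxyphenyl in place of quinolin-2-yl giving a 2.5-fold lower number from compound 3 to compound 4 (0.40 log units; beyond the scatter) and hydroxy in place of dimethylamino on an aromatic carbon giving a 5.0-fold lower number from compound 1 to compound 4 (0.70 log units; beyond the scatter). Fluoro in place of chloro on an aromatic carbon, a change not read before, gives no change at the digits printed from compound 2 to compound 4 (within the scatter) and so does not separate these two halogens in this series. No measurement on hand accounts for any of these steps.

On these data alone, whether the lower numbers depend on hydroxy itself remains open, and a methoxy group or a primary amine on that aromatic carbon would test this. As far as these compounds go, the bromo group shared by all four compounds also stays unvaried, so the effect of a nitrile in its place is unknown.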